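Compound 4: a chloro in place of a fluoro

A few compounds are considered here, and "the series" means these few. Any claim that something is new, unique, unknown or untested is made for them only; others in the source may bear on it.

Three compounds share one core and differ only in the group on an aromatic nitrogen: compound 1 `CCc1ccc(-n2nc(-c3ccc(C(F)(F)F)cc3O)nc2-c2ccccc2O)cc1`, compound 2 `CC(C)c1ccc(-n2nc(-c3ccc(C(F)(F)F)cc3O)nc2-c2ccccc2O)cc1` and compound 3 `Oc1cc(C(F)(F)F)ccc1-c1nc(-c2ccccc2O)n(-c2ccc(F)cc2)n1`. In a functional assay on PC-12 cells (Rattus norvegicus) for cytotoxicity, read by MTT assay, with stated times of 2 h and 24 h, tested at 1 uM (on this read-out higher numbers stand for a stronger effect at the one concentration tested and lower numbers for a weaker effect), compound 1 gives 64.4%, compound 2 gives 69.7% and compound 3 gives 67.2%; the three numbers lie within the scatter of one another, so compound 3 stands level with both companions. Compound 4 `Oc1cc(C(F)(F)F)ccc1-c1nc(-c2ccccc2O)n(-c2cccc(Cl)c2)n1` carries 3-chlorophenyl in place of 4-fluorophenyl on an aromatic nitrogen. The measured steps that touch this same group, a number 2.8 percentage points higher from compound 1 to compound 3 (within the scatter) and a number 2.5 percentage points lower from compound 2 to compound 3 (within the scatter), both stay within the scatter, so no step beyond the scatter is expected for compound 4, that is a number 0.2 percentage points lower from compound 3 to compound 4 (within the scatter). Compound 4 is therefore estimated to give 67%, with a range from 57% to 77%.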

Compound 4, a percentage reported as activity, at one concentration (the size of the read-out at that concentration, not a potency): 72.3%
Compound 4: middle estimate off by 5.3 percentage points, on the low side, within the range that was stated.
By their numbers in this assay, from the lowest: compounds 1, 3, 2 and 4 (each within the scatter of the next).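

In this assay, 3-chlorophenyl on the aromatic nitrogen gives steps that all stay within the scatter: a number 5.1 percentage points higher from compound 3 to compound 4 (within the scatter), a number 2.6 percentage points higher from compound 2 to compound 4 (within the scatter) and a number 7.9 percentage points higher from compound 1 to compound 4 (within the scatter). The position therefore takes a chlorine-bearing 3-substituted phenyl group as well as the three 4-substituted phenyl groups, with no difference that this read-out can resolve. No evidence is available that bears on this result.

Going by these compounds, it remains open whether 4-chlorophenyl would match 3-chlorophenyl here. On these data alone, it also remains open whether an amine or a carboxylic acid on this phenyl ring would give a step beyond the scatter.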